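The source may report more compounds than this note shows. Statements on the series, on what has been measured and on what is new or still open speak of the compounds shown alone.

In a functional assay on A-431 cells (Homo sapiens) for inhibition, read by sulforhodamine B assay, with a stated time of 2 days (a lower number here means a stronger inhibitor of growth, a higher number a weaker inhibitor of growth), compound 1 `CC1=C(C(=O)Nc2cccc([N+](=O)[O-])c2)C(c2ccc(O)cc2O)NC(NN2C(=O)/C(=C\c3ccco3)SC2=S)=N1` gives 28900 nM and compound 2 `CC1=C(C(=O)Nc2cccc([N+](=O)[O-])c2)C(c2ccc(O)cc2O)NC(NN2C(=O)/C(=C\c3cccs3)SC2=S)=N1` gives 2780 nM, so compound 2 has the lower of the two numbers and is the stronger inhibitor of growth so far. The next structure is compound 3 `CC1=C(C(=O)Nc2cccc([N+](=O)[O-])c2)C(c2ccc(O)cc2O)NC(NN2C(=O)/C(=C\c3ccccc3)SC2=S)=N1`, and the change is phenyl in place of thiophen-2-yl on a double-bonded chain carbon bound to a double-bonded ring carbon. Going by the values given here, only one measured step bears on this swap: the exchange at the same place that gave a 10-fold lower number from compound 1 to compound 2 (1.02 log units; beyond the scatter), a large step. It shows that the number can move strongly with the ring held there, but two compounds give no trend that predicts a phenyl. A moderate move towards a higher number is expected, although a lower number cannot be ruled out. The estimated change is a 1.6-fold higher number from compound 2 to compound 3 (0.21 log units; within the scatter). For compound 3 the expected value is 4500 nM, with an estimated range of 1300 nM to 16000 nM.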

Compound 3, concentration for 50% growth inhibition: 24300 nM
Compound 3: middle estimate off by 5.4-fold (0.73 log units), on the low side; measured number above the stated range.
By their numbers in this assay, from the lowest: compound 2; then compounds 3 and 1 (each within the scatter of the next).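

In this assay, the phenyl group, a six-membered aromatic ring of carbon only, does not keep the gain seen with thiophen-2-yl at this place: the swap gives an 8.7-fold higher number from compound 2 to compound 3 (0.94 log units; beyond the scatter). Compared with furan-2-yl, phenyl gives a 1.2-fold lower number from compound 1 to compound 3 (0.08 log units; within the scatter), so these two groups cannot be told apart here, and among the three compounds only compound 2, with thiophen-2-yl, stands out as the strongest inhibitor of growth. Nothing available explains why this one ring differs from the other two.

As far as these compounds go, all three groups at this place are unsubstituted aromatic rings, so it remains open how a thiophen-2-yl carrying a methyl or a chlorine would behave. From the compounds shown here alone, how a ring-free group such as a longer alkyl chain, or a ring bearing an amine or a carboxylic acid, would compare also remains unknown.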